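Hydroxy added to the methoxyphenyl arm of compound 3

The source may hold more compounds than are shown below. What is called first, only, known or untested is meant among the compounds shown, and "the series" means these compounds.

Compound 1 `OC[C@H]1O[C@@H](n2cnc3c(NCc4ccc(F)cc4)ncnc32)[C@H](O)[C@@H]1O` — in a functional assay on MCF cells (Homo sapiens) for antiproliferative activity, with a stated time of 72 h (on this read-out lower numbers stand for stronger inhibition and higher numbers for weaker inhibition), compound 1 gives 21000 nM.
Compound 2 `OC[C@H]1O[C@@H](n2cnc3c(NCc4ccccc4Br)ncnc32)[C@H](O)[C@@H]1O` — in this assay compound 2 reaches only the limit > 166000 nM.
Compound 3 `COc1cccc(CNc2ncnc3c2ncn3[C@@H]2O[C@H](CO)[C@@H](O)[C@H]2O)c1` — in this assay compound 3 likewise reaches only the limit > 166000 nM.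

Compound 3 thus stands at the top of the measured range, sharing the limit of > 166000 nM in this assay, at which 2 of the 3 values shown sit, with compound 2. Compound 4 `COc1cccc(CNc2ncnc3c2ncn3[C@@H]2O[C@H](CO)[C@@H](O)[C@H]2O)c1O` differs from compound 3 by hydroxy in place of hydrogen on an aromatic carbon. For the measured compounds named here, the measured steps, an at least 7.9-fold higher number from compound 1 to compound 2 (0.89 log units; beyond the scatter) and an at least 7.9-fold higher number from compound 1 to compound 3 (0.89 log units; beyond the scatter), each swap the whole aryl group, and a step that the two limits leave unreadable from compound 2 to compound 3 runs between two limits; none of them tests a hydroxy added onto the 3-methoxyphenyl, so no step bears directly on this change. With compound 3 at a limit, compound 4 is expected to stay near that limit, a step of an at least 1.1-fold lower number from compound 3 to compound 4 (0.04 log units; that floor lies within the scatter), and its value is estimated at 150000 nM, within 30000 nM to 600000 nM.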

Compound 4, half-maximal inhibitory concentration: 20200 nM
Compound 4: middle estimate off by 7.4-fold (0.87 log units), on the high side, and the stated range ends above it.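

On the 3-methoxyphenyl arm, hydroxy in place of hydrogen, ortho to the methoxy group, gives an at least 8.2-fold lower number from compound 3 to compound 4 (0.91 log units; beyond the scatter); earlier steps only swapped the whole aryl group. The 2-hydroxy-3-methoxyphenyl arm also gives an at least 8.2-fold lower number from compound 2 to compound 4 (0.91 log units; beyond the scatter), yet a 1.0-fold lower number from compound 1 to compound 4 (0.02 log units; within the scatter) leaves it level with the 4-fluorophenyl arm. Compound 3 stands at a limit, so the step from it has only a floor: the limit of > 166000 nM in this assay, at which 2 of the 4 values shown sit. The compounds shown leave open whether an amine or a carboxylic acid at this position would serve as the hydroxy does. They also leave open whether hydroxy would give such a step without the methoxy group.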